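The source may hold more compounds than are shown below. What is called first, only, known or untested is meant among the compounds shown, and "the series" means these compounds.

Of the compounds shown here, three have so far been measured in an assay on isolated protein for inhibition of Flap endonuclease 1 (Homo sapiens); a higher number here means a weaker inhibitor, a lower number a stronger inhibitor. Compound 1 `CC(=O)Nc1cccc2c(=O)n(O)c(=O)[nH]c12` gives 38 nM, compound 2 `O=c1cc(-c2ccccc2)[nH]c(=O)n1O` gives 630 nM, and compound 3 `O=C(c1nc(-c2cccs2)[nH]c(=O)c1O)N1CCCC1` gives 13700 nM. Compound 3 thus stands at the highest of the three numbers and is the weakest inhibitor among them: compound 2 sits a long way lower, and compound 1 lower still, with both gaps well beyond the scatter of repeated measurements.

Compound 4 `O=C(Nc1cccnc1)c1nc(-c2cccs2)[nH]c(=O)c1O` has not yet been measured. It differs from compound 3 in a single place: (pyridin-3-yl)amino in place of pyrrolidin-1-yl on a carbonyl carbon. Among the measured compounds shown here, no step between two measured compounds of this kind is available, so there is nothing to copy from, and the expectation rests only on the size of the change and on where compound 3 stands. The amide is rebuilt from a ring closed on its nitrogen to an open one that carries a hydrogen on the nitrogen and an aromatic ring, a change large enough that a shift in the number would not be surprising, although its direction is uncertain. A modest move towards a lower number is expected, estimated as a 2.3-fold lower number from compound 3 to compound 4 (0.36 log units; beyond the scatter). Compound 4 is therefore expected to give 6000 nM, within a range from 1500 nM to 25000 nM.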

Compound 4, half-maximal inhibitory concentration: 8600 nM
For compound 4 the middle estimate is 1.4-fold (0.16 log units) below the measured one; low and high end bracket the measured number.
By their numbers in this assay, from the lowest: compound 1; then compound 2; then compounds 4 and 3 (each within the scatter of the next).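

Among the compounds shown here, the earlier compounds offered no step at all, so this is the first direct look at what the group on a carbonyl carbon does in this assay: putting (pyridin-3-yl)amino in place of pyrrolidin-1-yl gives (a 1.6-fold lower number from compound 3 to compound 4 (0.20 log units; within the scatter)), which means compound 3 and compound 4 cannot be told apart. The swap is a large one, since a five-membered non-aromatic ring with no hydrogen-bond donor or acceptor gives way to a six-membered aromatic ring on an amide nitrogen that carries a hydrogen, yet in this one pair that rebuilding leaves the number within the scatter. No supporting measurement bears on why this is so.

On these data alone, what remains open is whether any group at this place can shift the number beyond the scatter, for instance a phenylamino group, which would lack the pyridine ring nitrogen, or a longer chain ending in an amine. With a single step on one core, it is also unknown whether the same swap would behave alike on the core of compound 1 or compound 2.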